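The source may report more compounds than this note shows. Statements on the series, on what has been measured and on what is new or still open speak of the compounds shown alone.

Of the compounds shown here, three sharing one core have been measured in a toxicity assay on WI-38 cells (Homo sapiens) for cytotoxicity, read by MTT assay, with a stated time of 48 h; a lower number here means a stronger inhibitor, a higher number a weaker inhibitor. Compound 1 `O=C(/C=C/c1ccc2c(c1)B(O)OC2)c1cccnc1` gives 76200 nM there, compound 2 `O=C(/C=C/c1ccc2c(c1)B(O)OC2)c1ccc(Cl)cc1` gives 24700 nM, and compound 3 `O=C(/C=C/c1ccc2c(c1)B(O)OC2)c1cccc(O)c1` gives 26400 nM. Compound 2 has the lowest number of the three, although its step to compound 3 lies within the scatter. Compound 4 `O=C(O)c1ccc(C(=O)/C=C/c2ccc3c(c2)B(O)OC3)cc1` differs from compound 2 by carboxy in place of chloro on an aromatic carbon. The steps measured so far, a 3.1-fold lower number from compound 1 to compound 2 (0.49 log units; beyond the scatter) and a 2.9-fold lower number from compound 1 to compound 3 (0.46 log units; beyond the scatter), exchange the whole ring on the carbonyl carbon, while a 1.1-fold higher number from compound 2 to compound 3 (0.03 log units; within the scatter) swaps one group on that ring for another; none introduces a carboxy. Because a 1.1-fold higher number from compound 2 to compound 3 (0.03 log units; within the scatter) lies within the scatter, the step of a 1.2-fold higher number from compound 2 to compound 4 (0.08 log units; within the scatter) is expected to be small, with no change beyond the scatter. Compound 4 is therefore estimated at 30000 nM, within a range from 10000 nM to 90000 nM.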

Compound 4, half-maximal inhibitory concentration: > 100000 nM
Compound 4: no number, only a limit; the forecaster's own chance of this, stated with the estimate: 10%; middle value at least 3.3-fold (0.52 log units) from the limit.
By their numbers in this assay, from the lowest: compounds 2 and 3 (each within the scatter of the next); then compound 1. At a limit, above all of these: compound 4.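

In this assay compound 4 has no number, only a limit: the limit of > 100000 nM in this assay, at which 1 of the 4 values shown sits.

Carboxy in place of chloro, on an aromatic carbon para to a large group, gives an at least 4.0-fold higher number from compound 2 to compound 4 (0.60 log units; beyond the scatter), so the number does respond to the group held at this place. From the compounds shown here alone, the earlier step from compound 2 stayed within the scatter, whereas this one lies beyond it, and its full size remains unknown.

Going by these compounds, how far compound 4 lies past its limit stays open. So does whether a methyl ester or an amine on this carbon would give a step of similar size.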